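The source may report more compounds than this note shows. Statements on the series, on what has been measured and on what is new or still open speak of the compounds shown alone.

Measured so far:
compound 1 `COc1ccc2ncc(S(=O)(=O)c3ccc(C)c(F)c3)c(N3CCC(C)CC3)c2c1` — 73% in an assay on isolated protein for displacement of a labelled ligand from metabotropic glutamate receptor 5 (Homo sapiens), with a stated time of 60 min, tested at 1 uM; a lower number here means less inhibition, a higher number more inhibition at the concentration tested (going by the name of the read-out)
compound 2 `NC(=O)C1CCN(c2c(S(=O)(=O)c3ccccc3)cnc3ccccc23)CC1` — 24.8% in this assay

Compound 2 stands lowest of the two numbers in this assay; compound 1 lies higher by a gap beyond the scatter. Going by the values given here, no pair of measured compounds differing in one place is available, so no measured step guides the next change. Compound 3 `CN1CCN(c2c(S(=O)(=O)c3ccccc3)cnc3ccccc23)CC1` differs from compound 2 by 4-methylpiperazin-1-yl in place of 4-carbamoylpiperidin-1-yl on an aromatic carbon. Among the compounds with values here, with no matched step to lean on, only a small change in this assay is expected, in either direction, likely not beyond the scatter. The step of a number 5.2 percentage points higher from compound 2 to compound 3 (within the scatter) is therefore expected to be modest. Compound 3 is estimated at 30%, with a range from 8% to 58%.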

Compound 3, a percentage reported as inhibition, at one concentration (the size of the read-out at that concentration, not a potency): 7.7%
For compound 3 the middle estimate is 22.3 percentage points above the measured one; measured number below the stated range.
By their numbers in this assay, from the lowest: compound 3; then compound 2; then compound 1.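

Going by these compounds alone, the aromatic carbon opposite the ring nitrogen is the first place with a matched step: 4-methylpiperazin-1-yl in place of 4-carbamoylpiperidin-1-yl gives a number 17.1 percentage points lower from compound 2 to compound 3 (beyond the scatter) in this assay. The read-out on this core therefore responds to the group at this carbon, with the phenylsulfonyl group held constant. No measured property accounts for this step.

Going by these compounds, how morpholin-4-yl or unsubstituted piperazin-1-yl would read at this carbon remains open. Compound 1 differs from compound 2 and compound 3 in more than one place, so what sets its number apart is also unresolved.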